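This account rests on a few compounds, and the source may have more. Where it says the series, first, only, none or still open, it means among the compounds named here.

Measured in a functional assay on LoVo cells (Homo sapiens) for cytotoxicity, read by colorimetric assay and MTT assay; a lower number here means a stronger inhibitor, a higher number a weaker inhibitor:
- compound 1 `COc1ccc(-c2cc3c(OC)cc(OC)cc3n(CCCC#N)c2=O)cc1`: 10000 nM
- compound 2 `COc1ccc(-c2cc3c(OC)cc(OC)cc3n(CC(=O)OCc3ccccc3)c2=O)cc1`: 10000 nM

In this assay compound 2 gives 10000 nM, level with compound 1. Compound 3 `COc1ccc(-c2cc3c(OC)cc(OC)cc3n(CC(=O)O)c2=O)cc1` differs from compound 2 by one change: hydrogen in place of benzyl on an oxygen next to a carbonyl group. Going by the values given here, only one measured step bears on it, no change at the digits printed from compound 1 to compound 2 (within the scatter), which alters the same chain on the aromatic nitrogen and stays within the scatter. With that single step as the guide, no shift in either direction is expected. The expected step is no change at the digits printed from compound 2 to compound 3 (within the scatter), none beyond the scatter. Compound 3 is estimated at 10000 nM, with an expected range of 4000 nM to 25000 nM.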

Compound 3, half-maximal inhibitory concentration: 10000 nM
For compound 3 middle estimate and measured number coincide at the digits printed; measured number inside the range.
By their numbers in this assay, from the lowest: compounds 1, 2 and 3 (each within the scatter of the next).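

In this assay, taking the benzyl off the oxygen next to a carbonyl group gives no change at the digits printed from compound 2 to compound 3 (within the scatter) and so leaves the number where it stood. The free carboxy group thus sits level with both the benzyloxycarbonyl and the 2-cyanoethyl groups, with no change at the digits printed from compound 1 to compound 3 (within the scatter) as the step from the nitrile chain, so three different chain ends on the aromatic nitrogen read alike here. Going by these compounds, whether an amine, an amide or a longer chain at this place would move the number stays open. Nothing at hand explains why these three chain ends read alike.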